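The compounds below may be only part of what the source reports. "The series", "measured", "known", "first", "only" and "open" are said of these compounds alone.

Compound 3 `FC(F)(F)c1ccc(CSc2nc(N3CCN(c4ccccc4)CC3)cc(C(F)(F)F)n2)cc1` carries a phenyl on an amine nitrogen in a ring of the shared core. In a functional assay on MCF7 cells (Homo sapiens) for inhibition, read by MTT assay, with a stated time of 72 h (on this read-out higher numbers stand for weaker inhibition and lower numbers for stronger inhibition), compound 3 gives only a limit, > 50000 nM, not a number. Compound 1 `FC(F)(F)c1ccc(CSc2nc(N3CCNCC3)cc(C(F)(F)F)n2)cc1` gives 10700 nM and compound 2 `CCN1CCN(c2cc(C(F)(F)F)nc(SCc3ccc(C(F)(F)F)cc3)n2)CC1` gives 22000 nM, so the steps of an at least 4.6-fold higher number from compound 1 to compound 3 (0.66 log units; beyond the scatter) and an at least 2.2-fold higher number from compound 2 to compound 3 (0.35 log units; beyond the scatter) both run toward weaker inhibition, as does a 2.1-fold higher number from compound 1 to compound 2 (0.31 log units; beyond the scatter). Compound 4 `FC(F)(F)c1ccc(CSc2nc(N3CCN(c4ccccn4)CC3)cc(C(F)(F)F)n2)cc1` differs from compound 3 by pyridin-2-yl in place of phenyl on an amine nitrogen in a ring. Going by the values given here, no measured step exchanges one aromatic ring for another on this nitrogen; the measured steps show only that substitution there weakens inhibition, with compound 3 already at the limit. The step of a number no higher from compound 3 to compound 4 (the limit leaves the size open) is therefore expected to stay within the scatter. Compound 4 is estimated at 50000 nM, within 20000 nM to 150000 nM, most likely again reported as a limit.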

Compound 4, half-maximal inhibitory concentration: > 50000 nM
Compound 4 gave a limit, no number; the forecaster's own chance of this, stated with the estimate: 60%; the middle value sits exactly at the limit.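

In this assay, the weakening seen with phenyl on this amine nitrogen also holds for pyridin-2-yl, with an at least 4.6-fold higher number from compound 1 to compound 4 (0.66 log units; beyond the scatter) and an at least 2.2-fold higher number from compound 2 to compound 4 (0.35 log units; beyond the scatter). The ring nitrogen of pyridin-2-yl therefore does not bring compound 4 back under the limit, which is a limit and not a number. The exchange of phenyl for pyridin-2-yl itself cannot be read, because compound 3 and compound 4 both stop at the same limit: the limit of > 50000 nM in this assay, at which 2 of the 4 values shown sit.

Going by these compounds, how far either aromatic ring lies beyond that limit stays open. Also open, on these data alone, is whether a methyl or a 2-hydroxyethyl group on this nitrogen would keep inhibition closer to that of compound 1.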